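A few compounds are considered here, and "the series" means these few. Any claim that something is new, unique, unknown or untested is made for them only; others in the source may bear on it.

Three compounds of a shared core have been characterised in an ADME assay on MDCK cells (Canis lupus familiaris) for cytotoxicity, read by microscopy, with a stated time of 48 h; a higher number here means that more compound is tolerated, a lower number that less compound is tolerated. Compound 1 `CCc1ccc(CN[C@@H]2C[C@H]3C[C@@H]([C@H]2C)C3(C)C)s1` carries an ethyl group on its five-membered ring; in this assay compound 1 gives 1560 nM. Compound 2 `C[C@H]1[C@H](NCc2sccc2-c2ccccc2)C[C@H]2C[C@@H]1C2(C)C` carries a phenyl group instead, and in this assay compound 2 gives 12500 nM. Compound 3 `C[C@H]1[C@H](NCc2cncs2)C[C@H]2C[C@@H]1C2(C)C`, with a thiazole in place of the thiophene, reaches only a limit of the assay: in this assay compound 3 gives > 100000 nM, which is a limit rather than a number, as noted in the limit of > 100000 nM in this assay, at which 1 of the 3 values shown sits. Among the two plain numbers, compound 2 stands highest, and its gap to compound 1 lies beyond the usual scatter.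

Compound 4 `C[C@H]1[C@H](NCc2sccc2C2CC2)C[C@H]2C[C@@H]1C2(C)C` is not yet measured. It differs from compound 2 by cyclopropyl in place of phenyl on an aromatic carbon. Going by the values given here, no measured pair shows this kind of exchange, so its effect is open. The cyclopropyl group is smaller than the phenyl group, and compound 1 with its ethyl group gave a lower number than compound 2, so a modest fall is expected, though one that could well stay within the scatter. The step from compound 2 to compound 4 is estimated at a 2.1-fold lower number from compound 2 to compound 4 (0.32 log units; beyond the scatter). For compound 4 in this assay an estimated value of 6000 nM is expected, with a likely range from 1500 nM to 25000 nM.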

Compound 4, minimum cytotoxic concentration: 25000 nM
Beside the measured number, compound 4's estimate is 4.2-fold (0.62 log units) below it, and the stated range covers the measured number.
By their numbers in this assay, from the lowest: compound 1; then compounds 2 and 4 (each within the scatter of the next). At a limit, above all of these: compound 3.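

In this assay, going by these compounds alone, the exchange of cyclopropyl for phenyl gives a 2.0-fold higher number from compound 2 to compound 4 (0.30 log units; within the scatter), the first step between compounds that differ in one place. On this aromatic carbon, two ring bonds from the ring sulfur, a six-membered aromatic ring of carbon only and a three-membered non-aromatic ring can thus replace each other with no change that stands out from the scatter. No measurement shown accounts for this result.

The compounds shown leave open how an amine, a carboxylic acid or a longer chain on this same aromatic carbon would read in this assay. They also leave open whether cyclopropyl in place of phenyl would give a similar result elsewhere on the five-membered ring.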